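The source may report more compounds than this note shows. Statements on the series, on what has been measured and on what is new or still open speak of the compounds shown alone.

Measured so far in a physicochemical assay for lipophilicity, read by HPLC; on this read-out lower numbers stand for lower lipophilicity and higher numbers for higher lipophilicity:
- compound 1 `COc1ccc(NC[C@@H](O)COc2ccc(N3C[C@H](CNC(C)=O)OC3=O)cc2F)cc1`: 1.15
- compound 2 `CC(=O)NC[C@H]1CN(c2ccc(OC[C@H](O)CNc3ccc(C#N)cc3)c(F)c2)C(=O)O1`: 1.29
- compound 3 `CC(=O)NC[C@H]1CN(c2ccc(OC[C@@H](O)CNC3CC3)c(F)c2)C(=O)O1`: 0.02

Compound 3 stands lowest of the three, beyond the scatter from both compound 1 and compound 2. The next compound for measurement in this assay is compound 4 `CC(=O)NC[C@H]1CN(c2ccc(OC[C@H](O)CNCCC(C)C)c(F)c2)C(=O)O1`, which departs from compound 3 by a single change: 1-hydroxy-2-(isopentylamino)ethyl in place of 2-(cyclopropylamino)-1-hydroxyethyl on a saturated chain carbon bound to an oxygen on an aromatic ring.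

Going by the values given here, the only measured step is a number 0.14 log units higher from compound 1 to compound 2 (within the scatter). It concerns a different exchange, cyano in place of methoxy on an aromatic carbon, so it gives no direct measure of the present change. Among the compounds with values here, no measured step covers this exchange of amino side chains, which leaves only the counted change and the values themselves as guides. Compound 1 at 1.15 and compound 2 at 1.29 mark roughly the upper region that seems reachable in this small set.

On that thin basis, a rise beyond the scatter is expected, and the expected size is a number 0.88 log units higher from compound 3 to compound 4 (beyond the scatter). The estimate for compound 4 is 0.9, with an expected range from 0.4 to 1.4.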

Compound 4, partition coefficient: 1.19
Compound 4: middle estimate off by 0.29 log units, on the low side; the range from low to high includes it.
By their numbers in this assay, from the lowest: compound 3; then compounds 1, 4 and 2 (each within the scatter of the next).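

In this assay, going by these compounds alone, the exchange on a saturated chain carbon bound to an oxygen on an aromatic ring gives the first large measured step, a number 1.17 log units higher from compound 3 to compound 4 (beyond the scatter), showing that the substituent on the amine nitrogen can move this read-out well beyond the scatter. The same position also shows that a large change of group need not move it: isopentyl in place of 4-cyanophenyl gives a number 0.10 log units lower from compound 2 to compound 4 (within the scatter), and isopentyl in place of 4-methoxyphenyl gives a number 0.04 log units higher from compound 1 to compound 4 (within the scatter), so on this read-out the open chain of compound 4 is not separated from either aromatic group. No measurement shown accounts for the size of the step from the cyclopropyl group to the isopentyl group.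

The exchange removes the three-membered ring and also raises the heavy-atom count, so the compounds shown do not separate these two changes. An open n-propyl chain on the amine nitrogen would address the loss of the ring at a similar size, while a cyclopentyl or cyclohexyl ring there would address added carbon with a ring retained.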